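From Nitro to Chloro at the Limit

A few compounds are considered here, and "the series" means these few. Any claim that something is new, unique, unknown or untested is made for them only; others in the source may bear on it.

In a functional assay on A549 cells (Homo sapiens) for inhibition, read by XTT assay, with a stated time of 48 h (a higher number here means a weaker inhibitor, a lower number a stronger inhibitor), compound 1 (`COc1ccc(C(=O)/C(=C/c2ccccc2F)CCOC(C)=O)cc1`) gives > 100000 nM, which is a limit and not a number. In this assay compound 2 (`COc1ccc(C(=O)/C(=C/c2ccc([N+](=O)[O-])cc2)CCOC(C)=O)cc1`) gives > 100000 nM, which is also only a limit. Compound 2 therefore stands with compound 1 at the limit of > 100000 nM in this assay, at which 2 of the 2 values shown sit, and neither compound has yet given a readable number.

The next analogue, compound 3 (`COc1ccc(C(=O)/C(=C/c2ccc(Cl)cc2)CCOC(C)=O)cc1`), keeps the shared core and carries chloro in place of nitro on an aromatic carbon, para to a large group: chloro in place of nitro on an aromatic carbon. Among the measured compounds shown here, the one measured step that bears on this change is a step that the two limits leave unreadable from compound 1 to compound 2, and it offers no size to carry over. No step beyond the scatter is therefore expected in this assay, and no direction can be assigned, although the limit could conceal a change that the data cannot foresee. The estimated step is a number no higher from compound 2 to compound 3 (the limit leaves the size open). A reading at the same limit is the likeliest outcome. For compound 3 the estimated value is 100000 nM, with an expected range from 30000 nM to 300000 nM.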

Compound 3, half-maximal inhibitory concentration: 86000 nM
Compound 3: the middle estimate sits 1.2-fold (0.07 log units) above what was measured, within the range that was stated.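

Chloro on this aromatic carbon, para to a large group, gives the first reading in this assay that is a number and not a limit. The change from nitro to chloro is an at least 1.1-fold lower number from compound 2 to compound 3 (0.06 log units; that floor lies within the scatter), and the change from 2-fluorophenyl to 4-chlorophenyl is an at least 1.1-fold lower number from compound 1 to compound 3 (0.06 log units; that floor lies within the scatter); both are floors, so their true size stays open and neither is shown to lie beyond the scatter. The step between compound 1 and compound 2 still cannot be read, and most of the series remains at the limit: the limit of > 100000 nM in this assay, at which 2 of the 3 values shown sit.

The compounds shown do not tell whether a readable number is particular to chloro, or whether bromo, methoxy or an amine on the same aromatic carbon would also give one. They also leave open how the number would respond to a longer chain or a carboxylic acid on the part of the shared core that carries the ester.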